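A few compounds are considered here, and "the series" means these few. Any claim that something is new, unique, unknown or untested is made for them only; others in the source may bear on it.

Measured compounds and their values:
Compound 1, `COc1ccccc1/C=C/C(=O)c1cc(NC(C)=O)ccc1O`, gives > 125000 nM, a limit of the assay.
Compound 2, `CC(=O)Nc1ccc(O)c(C(=O)/C=C/c2ccccc2F)c1`, gives > 125000 nM, also a limit.
Compound 3, `COc1ccc(-c2cc(=O)c3cc(N)ccc3o2)cc1`, gives 124000 nM.

All three were tested in an ADME assay on THP-1 cells (Homo sapiens) for cytotoxicity, read by flow cytometry and propidium iodide staining, with a stated time of 72 h; a lower number here means a stronger inhibitor, a higher number a weaker inhibitor. The change from compound 1 to compound 2 is fluoro in place of methoxy on an aromatic carbon, and its step, a step that the two limits leave unreadable from compound 1 to compound 2, cannot be read because of the limit of > 125000 nM in this assay, at which 2 of the 3 values shown sit. Compound 4, `Nc1ccc2oc(-c3ccc(F)cc3)cc(=O)c2c1`, is not yet measured; it differs from compound 3 by fluoro in place of methoxy on an aromatic carbon. Among the measured compounds shown here, this is the same kind of change as the one from compound 1 to compound 2, but not the same: there the fluoro sits ortho to a large group, here para to a large group. How the core of compound 1 and the core of compound 3 differ is not broken down here. For compound 4 a small step, a 1.0-fold higher number from compound 3 to compound 4 (0.02 log units; within the scatter), is expected, resting on compound 3 giving 124000 nM and on the earlier step being unreadable. Compound 4 is therefore estimated at 130000 nM, between 60000 nM and 300000 nM.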

Compound 4, half-maximal inhibitory concentration: 10000 nM
Beside the measured number, compound 4's estimate is 13-fold (1.11 log units) above it, outside the stated range (below it).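

In this assay, fluoro in place of methoxy on the core of compound 3 gives a 12-fold lower number from compound 3 to compound 4 (1.09 log units; beyond the scatter), so on this core the change has a large effect. The same kind of change on the core of compound 1 cannot be read, because the values of compound 1 and compound 2 are both limits of the assay: the limit of > 125000 nM in this assay, at which 2 of the 4 values shown sit. Carrying the change across cores therefore remains untested: the large step is shown for one pair only, and nothing shows that it would also appear on the core of compound 1.

As far as these compounds go, it remains open whether the lower number comes from losing methoxy or from gaining fluoro. A chloro group or a hydroxyl group in the same place could help separate the two.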